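Swapping One Group: From Methylamino to Piperidin-1-yl

The source may hold more compounds than are shown below. What is called first, only, known or untested is meant among the compounds shown, and "the series" means these compounds.

Three related compounds have been tested in a toxicity assay on J774.A1 cells (Mus musculus) for cytotoxicity, read by SYBR Green assay, with a stated time of 1 h; on this read-out lower numbers stand for an effect already at smaller amounts and higher numbers for an effect only at larger amounts of compound. In it, compound 1 (`CN(C)c1ccc2cc(-c3cccc(Cl)c3Cl)c(N)nc2c1`) gives 4900 nM, compound 2 (`Nc1nc2cc(N3CCCCC3)ccc2cc1-c1cc(Cl)cc(Cl)c1`) gives 6800 nM and compound 3 (`CNc1ccc2cc(-c3cn(C)c4ccccc34)c(N)nc2c1`) gives 4100 nM. All three numbers lie within the usual scatter of one another, so compound 3 cannot be told apart from the other two on this evidence.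

The next compound to be measured is compound 4 (`Cn1cc(-c2cc3ccc(N4CCCCC4)cc3nc2N)c2ccccc21`). It matches compound 3 except at one place, where it has piperidin-1-yl in place of methylamino on an aromatic carbon. A small group without a ring thus gives way to a larger group built on a six-membered non-aromatic ring.

For the measured compounds named here, no pair of measured compounds shows this swap on its own, so any expectation rests on indirect evidence. Compound 2 already carries piperidin-1-yl, and its 6800 nM does not stand apart from the other two compounds. Only a modest shift is therefore expected, towards a slightly higher number and not beyond the scatter. The expected step is a 1.3-fold higher number from compound 3 to compound 4 (0.13 log units; within the scatter). For compound 4 the estimated value is 5500 nM, with an expected range from 2500 nM to 12000 nM.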

Compound 4, half-maximal effective concentration: 560 nM
Compound 4: the middle estimate sits 9.8-fold (0.99 log units) above what was measured; the measured number lies below the stated range.
By their numbers in this assay, from the lowest: compound 4; then compounds 3, 1 and 2 (each within the scatter of the next).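

In this assay this position proves sensitive to its group: piperidin-1-yl in place of methylamino on this aromatic carbon gives a 7.3-fold lower number from compound 3 to compound 4 (0.86 log units; beyond the scatter) and so produces the only step shown here, one that lies beyond the scatter. The earlier numbers, all within the scatter of one another, gave no hint of this, and piperidin-1-yl alone does not go with a low number: compound 2 also carries it and gives 6800 nM while differing from compound 4 only in the aromatic group at another place on the core. No measurement explains the change, and the swap alters size, ring content and hydrogen-bond donor count together, so these features cannot be separated here.

The compounds shown leave open whether pyrrolidine with its smaller ring, morpholine with its added ring oxygen or an open-chain diethylamino group at this position would also give a number as low as that of compound 4. They also leave open whether the same swap would give a similar step with the aromatic groups of compound 1 or compound 2 elsewhere on the core.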